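This account rests on a few compounds, and the source may have more. Where it says the series, first, only, none or still open, it means among the compounds named here.

Working notes on the series. Compound 1 `CC(=O)c1ccc(NC(=O)C2CC(O)CN2S(=O)(=O)c2ccc(C)cc2)cc1` in a functional assay for inhibition, read by spectrophotometry, with a stated time of 20 min, tested at 5 mg/mL (on this read-out higher numbers stand for a stronger effect at the one concentration tested and lower numbers for a weaker effect), gives 13%. Going by the values given here, compound 2 `CC(=O)c1ccc(NC(=O)C2CC(O)CN2S(=O)(=O)c2ccc([N+](=O)[O-])cc2)cc1` gives 70.7% in this assay, the higher of the two numbers measured so far, with the single measured step being a number 57.7 percentage points higher from compound 1 to compound 2 (beyond the scatter). Compound 3 `CC(=O)c1ccc(NC(=O)C2CC(O)CN2S(=O)(=O)c2ccccc2)cc1` differs from compound 2 by hydrogen in place of nitro on an aromatic carbon. Among the compounds with values here, that methyl-to-nitro step is the only one bearing on this change; taking the nitro away is expected to undo much of it, so a large fall in this assay is expected for compound 3, a number 50.7 percentage points lower from compound 2 to compound 3 (beyond the scatter). Compound 3 is therefore estimated at 20%, in the range 5% to 45%.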

Compound 3, a percentage reported as inhibition, at one concentration (the size of the read-out at that concentration, not a potency): 58.7%
For compound 3 the middle estimate is 38.7 percentage points below the measured one; the whole stated range lies below it.
By their numbers in this assay, from the lowest: compound 1; then compound 3; then compound 2.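

With hydrogen on this aromatic carbon, para to a large group, the effect stays high: the result is a number 12 percentage points lower from compound 2 to compound 3 (beyond the scatter), but a number 45.7 percentage points higher from compound 1 to compound 3 (beyond the scatter). Most of the gap between compound 1 and compound 2 therefore goes with the presence of methyl, and the nitro adds only a modest further part, giving the order methyl, hydrogen, nitro among these three compounds. Nothing available explains this order. Still open, from the compounds shown here alone, is where an amine, a carboxylic acid or a longer chain at this position would fall in that order.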